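From 3-fluorobenzyl to 4-chlorobenzyl: a small step expected

The compounds below may be only part of what the source reports. "The series", "measured", "known", "first", "only" and "open" are said of these compounds alone.

Compound 1 (`COc1ccc(S(=O)(=O)Oc2ccccc2/C=C(\C#N)C(=O)Nc2nnc(Cc3cccc4ccccc34)s2)cc1`) gives 4700 nM in a functional assay on HL-60 cells (Homo sapiens) for inhibition, read by CCK-8 assay, with a stated time of 48 h (on this read-out higher numbers stand for weaker inhibition and lower numbers for stronger inhibition), and compound 2 (`COc1ccc(S(=O)(=O)Oc2ccccc2/C=C(\C#N)C(=O)Nc2nnc(Cc3cccc(F)c3)s2)cc1`) gives 3880 nM on the same read-out, so these two cannot be ranked against each other. Among the measured compounds shown here, putting 3-fluorophenyl in place of naphthalen-1-yl produced a 1.2-fold lower number from compound 1 to compound 2 (0.08 log units; within the scatter) and that is the only measured step available. Compound 3 (`COc1ccc(S(=O)(=O)Oc2ccccc2/C=C(\C#N)C(=O)Nc2nnc(Cc3ccc(Cl)cc3)s2)cc1`) has not yet been measured. It carries 4-chlorophenyl in place of 3-fluorophenyl on a saturated chain carbon bound to an aromatic carbon, the same place that changed in the measured step. That step, a 1.2-fold lower number from compound 1 to compound 2 (0.08 log units; within the scatter), stayed small, so no change beyond the scatter is expected in this assay for this swap. The expected step is a 1.0-fold higher number from compound 2 to compound 3 (0.01 log units; within the scatter). A single earlier step is thin support for this expectation. Compound 3 is therefore expected at 4000 nM with an estimated range from 2000 nM to 8000 nM in this measurement.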

Compound 3, half-maximal inhibitory concentration: 4360 nM
For compound 3 the middle estimate is 1.1-fold (0.04 log units) below the measured one, and the stated range covers the measured number.
By their numbers in this assay, from the lowest: compounds 2, 3 and 1 (each within the scatter of the next).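

In this assay, putting 4-chlorophenyl in place of 3-fluorophenyl on a saturated chain carbon bound to an aromatic carbon gives a 1.1-fold higher number from compound 2 to compound 3 (0.05 log units; within the scatter), and putting it in place of naphthalen-1-yl gives a 1.1-fold lower number from compound 1 to compound 3 (0.03 log units; within the scatter). Three different aromatic groups at this position now lie within the scatter of one another, so a change of halogen and of its place on the ring, made together, leaves the number in the same range as the larger naphthalen-1-yl group. No supporting measurement is available to explain this flat result.

From the compounds shown here alone, all three groups at this position are aromatic carbon rings, so the effect of a saturated cyclohexyl ring, or of a ring carrying an amine or a carboxylic acid, remains open. Also open, going by these compounds, is what the halogen and its place on the ring each contribute separately, since 3-fluorophenyl and 4-chlorophenyl differ in both.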